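Sulfamoyl for hydroxy on a weak quinolinone imine

The compounds below may be only part of what the source reports. "The series", "measured", "known", "first", "only" and "open" are said of these compounds alone.

Measured so far:
compound 1, `O=c1[nH]c2ccccc2cc1/C=N/c1ccc(O)cc1`, 92100 nM
compound 2, `Cc1ccc2[nH]c(=O)c(/C=N/Nc3ccc([N+](=O)[O-])cc3[N+](=O)[O-])cc2c1`, "not active" (no number reported), reported without a number

For the measured compounds named here, compound 1 is the single compound with a number in a functional assay, read by spectrophotometry, with a stated time of 30 min; a higher number here means a weaker inhibitor, a lower number a stronger inhibitor; compound 2 stands beside it without one. Compound 1 is therefore the only anchor, and its value marks it as a weak inhibitor. Compound 3, `NS(=O)(=O)c1ccc(/N=C/c2cc3ccccc3[nH]c2=O)cc1`, has not been measured in this assay. It differs from compound 1 by sulfamoyl in place of hydroxy on an aromatic carbon. Going by the values given here, no pair of measured compounds shows the effect of such a change, so no size or direction for it can be read from these data. The expectation is a step of a 1.3-fold lower number from compound 1 to compound 3 (0.12 log units; within the scatter), which stays within the usual scatter. Compound 3 is therefore expected to give about 70000 nM, in a range from 15000 nM to 300000 nM.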

Compound 3, half-maximal inhibitory concentration: 266000 nM
The estimate for compound 3 lay 3.8-fold (0.58 log units) below the measured number, within the range that was stated.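

Placing sulfamoyl in place of hydroxy, on an aromatic carbon para to a large group, gives in this assay a 2.9-fold higher number from compound 1 to compound 3 (0.46 log units; beyond the scatter), a modest step toward weaker inhibition. For the compounds shown here, this is the first measured step at this position, and it shows that the number responds to the group placed there, with hydroxy the better of the two groups compared. No measurement shown explains why the number moves in this direction.

The compounds shown leave open how an amine, a carboxylic acid or a methoxy group on the same aromatic carbon would compare, and whether a plain hydrogen there would read closer to compound 1 or to compound 3. Going by these compounds alone, with only one step available, it also remains open whether this exchange would shift the number the same way on a different core.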